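Branching a Side Chain on Two Related Cores

The source may report more compounds than this note shows. Statements on the series, on what has been measured and on what is new or still open speak of the compounds shown alone.

Of the compounds shown here, three have so far been tested in an assay on membranes from HEK293 cells for displacement of a labelled ligand from adenosine receptor A2b (Homo sapiens), read by scintillation counting, with a stated time of 30 min, tested at 1 uM; a lower number here means less inhibition, a higher number more inhibition at the concentration tested (going by the name of the read-out). Compound 1 `CCCOC(=O)C1=C(C)N(C)C(=O)NC1c1ccoc1` gives 2%. Compound 2 `CC1=C(C(=O)OCC(C)C)C(c2ccoc2)NC(=O)N1C` differs from compound 1 only by methyl in place of hydrogen on a saturated chain carbon bound to two saturated chain carbons; in this assay compound 2 gives 1%. The step of a number 1 percentage points lower from compound 1 to compound 2 (within the scatter) is a flat one: the added branch carbon did nothing that can be told apart from the noise of repeated measurement. Compound 3 `CCCC(=O)C1=C(C)NC(=O)NC1c1cccs1` is built on a different core, and how its core differs from that of compound 1 is not broken down here. In this assay compound 3 gives 9%, which sits within the scatter of both compound 1 and compound 2, so none of the three can be called stronger or weaker than another.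

Compound 4 `CC1=C(C(=O)CC(C)C)C(c2cccs2)NC(=O)N1` has not yet been measured. It relates to compound 3 exactly as compound 2 relates to compound 1: the difference is methyl in place of hydrogen on a saturated chain carbon bound to two saturated chain carbons, made at the same place as before, so this is the same change seen once already. Because a number 1 percentage points lower from compound 1 to compound 2 (within the scatter) lay within the scatter, the expected step is a number 1 percentage points lower from compound 3 to compound 4 (within the scatter), also within the scatter. Compound 4 is therefore expected to give 8%, with a plausible range from 0% to 20%. This expectation rests on a single precedent on a different core, and an unmeasured compound may still surprise.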

Compound 4, a percentage reported as inhibition, at one concentration (the size of the read-out at that concentration, not a potency): 43%
Beside the measured number, compound 4's estimate is 35 percentage points below it; measured number outside the range, above it.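

In this assay, going from propylcarbonyl to isobutylcarbonyl on the core of compound 3 brings a number 34 percentage points higher from compound 3 to compound 4 (beyond the scatter) and so stands out clearly, whereas the same added methyl on the core of compound 1 gave a step that could not be told from the noise of repeated measurement. A result for this change on one core therefore cannot simply be carried over to the other as a fixed step: the same change on two cores in this assay, a number 1 percentage points lower (within the scatter) from compound 1 to compound 2 and a number 34 percentage points higher (beyond the scatter) from compound 3 to compound 4, 35 percentage points apart, beyond the scatter of two such steps

Among the compounds shown here, this shows that the effect of the added methyl depends on the core that carries it, but with only two pairs it does not show which of the features separating the two cores is responsible, nor that branching helps in general, and a single reading at one concentration is not a potency.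

The compounds shown leave open whether the rise on the core of compound 3 is special to the isobutylcarbonyl group or would also appear with a longer chain, such as pentylcarbonyl, or with a ring-bearing group, such as cyclopentylcarbonyl. They also leave open how a chain ending in an amine or a carboxylic acid would behave at this place on either core.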